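The source may report more compounds than this note shows. Statements on the series, on what has been measured and on what is new or still open speak of the compounds shown alone.

In a functional assay on blood (Platelet, Oryctolagus cuniculus) for inhibition, read by turbidimetry, with a stated time of 2 min (on this read-out higher numbers stand for weaker inhibition and lower numbers for stronger inhibition), compound 1 (`CCOc1ccc(S(=O)(=O)N2CCN(c3ccccc3C)CC2)cc1S(=O)(=O)N1CCN(c2ccccc2C)CC1`) reads 650 nM and compound 2 (`COc1ccc(S(=O)(=O)N2CCN(c3ccccc3F)CC2)cc1S(=O)(=O)N1CCN(c2ccccc2F)CC1`) reads 480 nM while compound 3 (`COc1ccc(S(=O)(=O)N2CCN(c3ccc(C)cc3)CC2)cc1S(=O)(=O)N1CCN(c2ccc(C)cc2)CC1`) reads 680 nM on the same scale. All three numbers lie within the usual scatter of one another, so compound 1 stands in one group with the other two and no order among them can be claimed. Compound 4 (`COc1ccc(S(=O)(=O)N2CCN(c3ccccc3C)CC2)cc1S(=O)(=O)N1CCN(c2ccccc2C)CC1`) differs from compound 1 by one small edit (hydrogen in place of methyl on a saturated chain carbon bound to an oxygen on an aromatic ring): hydrogen in place of methyl on a saturated chain carbon bound to an oxygen on an aromatic ring, which turns ethoxy to methoxy. Among the measured compounds shown here, no measured pair shows this edit alone. Still, compound 2 at 480 nM and compound 3 at 680 nM already carry methoxy, so no step beyond the scatter is expected in this assay here. The expected change is small, an estimated step of a 1.2-fold lower number from compound 1 to compound 4 (0.07 log units; within the scatter) that stays within the scatter. For compound 4 the estimate is 550 nM with an expected range from 300 nM to 1000 nM across repeat measurements.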

Compound 4, half-maximal inhibitory concentration: 360 nM
Compound 4: middle estimate off by 1.5-fold (0.18 log units), on the high side; measured number inside the range.
By their numbers in this assay, from the lowest: compounds 4, 2, 1 and 3 (each within the scatter of the next).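

Among the compounds shown here, this pair gives the first direct reading of ethoxy to methoxy on the core of compound 1. In this assay the edit gives a 1.8-fold lower number from compound 1 to compound 4 (0.26 log units; within the scatter) and so stays within the usual scatter, which means that at this place the methyl can go without a clear change in the number. Nothing here accounts for the size of this step.

From the compounds shown here alone, how a longer chain such as propoxy, or a hydroxyl group, would read at this place remains open. So does whether the same edit behaves alike on the core of compound 2.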